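The source may report more compounds than this note shows. Statements on the series, on what has been measured and on what is new or still open speak of the compounds shown alone.

Of the compounds shown here, three have been tested in a functional assay on KYSE-70 cells for antiproliferative activity against KYSE-70 cell line (Homo sapiens), read by MTT assay, with a stated time of 72 h (a higher number here means a weaker inhibitor, a lower number a stronger inhibitor), and of these only one gives an actual number. Compound 3 `O=C(Nc1cccc(F)c1)c1cc(=O)[nH]c2cc(-c3ccc(F)cc3)ccc12` is measured at 3300 nM. Compound 1 `O=C(Nc1ccc(Cl)cc1)c1ccnc2cc(Br)ccc12` reaches only the limit of the assay, reported as > 20000 nM. Compound 2 `O=C(Nc1cc(F)cc(F)c1)c1cc(=O)[nH]c2cc(O)ccc12` likewise stops at the assay limit, reported as > 20000 nM. So compound 3 stands alone as the single compound with a readable value, and two of the three results sit at the limit of > 20000 nM in this assay, at which 2 of the 3 values shown sit.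

Compound 4 `C#Cc1ccc2c(C(=O)Nc3cccc(F)c3)cc(=O)[nH]c2c1` is not yet measured. It differs from compound 3 in one place: ethynyl in place of 4-fluorophenyl on an aromatic carbon. Among the measured compounds shown here, no step between two measured compounds is available to gauge the effect of this exchange, so the expectation rests on compound 3 alone. Given the value of 3300 nM for compound 3 and the small size of the entering group, compound 4 is expected to lose some potency, with a step of a 2.1-fold higher number from compound 3 to compound 4 (0.33 log units; beyond the scatter) that may or may not exceed the scatter. Compound 4 is therefore estimated at 7000 nM, with a plausible range from 2500 nM to 20000 nM.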

Compound 4, half-maximal inhibitory concentration: 9500 nM
Estimate against measurement, compound 4: 1.4-fold (0.13 log units) below; the measured number falls inside the stated range.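

In this assay, among the compounds shown here, the exchange of 4-fluorophenyl for ethynyl on this aromatic carbon gives the first measured step at this position: a 2.9-fold higher number from compound 3 to compound 4 (0.46 log units; beyond the scatter). Replacing a ring of 7 heavy atoms with a group of 2 heavy atoms and no ring therefore weakens the compound, but only modestly, so within this pair the 4-fluorophenyl ring is not required for a readable value. Compound 4 joins compound 3 on the readable part of the scale, while the other two results remain limits of the assay: the limit of > 20000 nM in this assay, at which 2 of the 4 values shown sit.

A single step cannot show whether the loss follows from the number of atoms or from the missing ring. As far as these compounds go, how an amine, a carboxylic acid or a longer carbon chain on this same carbon would compare with these two groups also remains open.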